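Trimming a Biphenyl: Expected Loss in T-type Channel Inhibition

The compounds below may be only part of what the source reports. "The series", "measured", "known", "first", "only" and "open" are said of these compounds alone.

Compound 2 `CN(C)CCCCCSC1=Nc2ccccc2C(CC(=O)NCc2ccc(F)cc2)N1c1ccc(-c2ccccc2)cc1` holds the lower of the two numbers recorded so far in an assay on cells for inhibition of Voltage-dependent T-type calcium channel subunit alpha-1H (Homo sapiens), read by patch clamp (on this read-out lower numbers stand for stronger inhibition and higher numbers for weaker inhibition), giving 3140 nM. Compound 1 `O=C(CC1c2ccccc2N=C(SCCCCCN2CCCC2)N1c1ccccc1)NCc1ccc(F)cc1`, which differs from it in several places, gives 57400 nM, a gap beyond the usual scatter. Compound 3 `CN(C)CCCCCSC1=Nc2ccccc2C(CC(=O)NCc2ccc(F)cc2)N1c1ccccc1`, not yet measured, arises from compound 2 by hydrogen in place of phenyl on an aromatic carbon. Among the compounds with values here, no single-change step is recorded, so the direction rests on compound 1, whose phenyl-bearing structure gave 57400 nM, suggesting a step upward, likely beyond the scatter. For compound 3 the estimate is 15000 nM, ranging from 5000 nM to 50000 nM. This step is expected as a 4.8-fold higher number from compound 2 to compound 3 (0.68 log units; beyond the scatter).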

Compound 3, half-maximal inhibitory concentration: 832000 nM
Compound 3: middle estimate off by 55-fold (1.74 log units), on the low side; the measured number lies above the stated range.
By their numbers in this assay, from the lowest: compound 2; then compound 1; then compound 3.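

In this assay, 4-phenylphenyl cut back to phenyl gives a 260-fold higher number from compound 2 to compound 3 (2.42 log units; beyond the scatter), a large step that shows how much the number depends on the outer phenyl at this place. With phenyl held fixed, dimethylamino in place of pyrrolidin-1-yl gives a 14-fold higher number from compound 1 to compound 3 (1.16 log units; beyond the scatter), so the amine on the chain also moves the number, which compound 1 and compound 2, differing in several places, could not show apart. Nothing available explains either step. The compounds shown leave open whether methoxy or chlorine on that aromatic carbon would bring the number back down. As far as these compounds go, how piperidin-1-yl on the chain would compare also stays open.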